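Partial saturation of the hydroxynaphthyl ring in a urea series

The source may report more compounds than this note shows. Statements on the series, on what has been measured and on what is new or still open speak of the compounds shown alone.

Measured so far:
compound 1, `CN(C)C1(Cc2ccccc2)CCN(c2cc(C(F)(F)F)ccc2CNC(=O)Nc2ccc(NS(C)(=O)=O)c(F)c2)CC1`: 1160 nM
compound 2, `CN(C)C1(Cc2ccccc2)CCN(c2cc(C(F)(F)F)ccc2CNC(=O)Nc2cccc3ccc(O)cc23)CC1`: 0.46 nM

In an assay on CHO cells for displacement of a labelled ligand from transient receptor potential cation channel subfamily V member 1 (Homo sapiens), read by scintillation counting, with a stated time of 60 min (on this read-out lower numbers stand for stronger inhibition and higher numbers for weaker inhibition), compound 1 gives 1160 nM. Among the compounds with values here, compound 2 gives 0.46 nM, the lowest of the two numbers; its only neighbour is compound 1, with a 2500-fold lower number from compound 1 to compound 2 (3.40 log units; beyond the scatter). Compound 3, `CN(C)C1(Cc2ccccc2)CCN(c2cc(C(F)(F)F)ccc2CNC(=O)Nc2cccc3c2CC(O)CC3)CC1`, differs from compound 2 by 3-hydroxy-1,2,3,4-tetrahydronaphthalen-5-yl in place of 7-hydroxynaphthalen-1-yl on an amide-type nitrogen. Within the data shown here, no measured step addresses saturation of one ring of this group; the single step between compound 1 and compound 2 concerns a different replacement on the same nitrogen and so bears only loosely. A modest rise is expected, a 5.4-fold higher number from compound 2 to compound 3 (0.74 log units; beyond the scatter). Compound 3 is estimated at 2.5 nM, within 0.4 nM to 15 nM.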

Compound 3, inhibition constant: 0.95 nM
The estimate for compound 3 lay 2.6-fold (0.42 log units) above the measured number; low and high end bracket the measured number.
By their numbers in this assay, from the lowest: compound 2; then compound 3; then compound 1.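

In this assay, replacing 7-hydroxynaphthalen-1-yl with 3-hydroxy-1,2,3,4-tetrahydronaphthalen-5-yl gives only a modest change, a 2.1-fold higher number from compound 2 to compound 3 (0.31 log units; beyond the scatter), so a second aromatic ring is not required for a low number at this nitrogen, though the step lies beyond the scatter. Nearly all of the large difference from the 3-fluoro-4-(methanesulfonamido)phenyl group remains, a 1200-fold lower number from compound 1 to compound 3 (3.09 log units; beyond the scatter). Nothing measured here accounts for either step. Still open, from the compounds shown here alone, is whether the hydroxyl is needed at all: an amine or a methoxy group in its place on the non-aromatic ring could settle this.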